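Replacing the cyano group of compound 2

A few compounds are considered here, and "the series" means these few. Any claim that something is new, unique, unknown or untested is made for them only; others in the source may bear on it.

In a functional assay on GC3/MTK- cells (Homo sapiens) for inhibition (on this read-out higher numbers stand for weaker inhibition and lower numbers for stronger inhibition), compound 2 `C#CCN(Cc1ccc2nc(C)nc(O)c2c1)c1ccc(C#N)cc1` gives 5000 nM and compound 3 `C#CCN(Cc1ccc2nc(C)nc(O)c2c1)c1ccc(C#N)c(Cl)c1` gives 6700 nM, so the two lie within the scatter of each other. For compound 1 `C#CCN(Cc1ccc2nc(C)nc(O)c2c1)c1cccc(CO)c1` the assay gives only a limit, > 54000 nM. Compound 4 `C#CCN(Cc1ccc2nc(C)nc(O)c2c1)c1ccc(S(=O)(=O)N2CCN(C)CC2)cc1` has (4-methylpiperazin-1-yl)sulfonyl in place of cyano on an aromatic carbon. Among the measured compounds shown here, two measured steps bear on this change, though neither replaces the cyano alone. The first, an at least 10-fold lower number from compound 1 to compound 2 (1.03 log units; beyond the scatter), is large but exchanges the whole aryl group. The second, a 1.3-fold higher number from compound 2 to compound 3 (0.13 log units; within the scatter), stays within the scatter. The expected step, a 1.6-fold higher number from compound 2 to compound 4 (0.20 log units; within the scatter), is small, towards a higher number and within the scatter. Compound 4 is estimated at 8000 nM, with an expected range from 2000 nM to 30000 nM.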

Compound 4, half-maximal inhibitory concentration: > 10000 nM
Compound 4 ended at the assay's limit; the forecaster's own chance of this, stated with the estimate: 15%; middle value at least 1.2-fold (0.09 log units) away from the limit.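

Here the cyano itself is replaced, and the exchange for (4-methylpiperazin-1-yl)sulfonyl on this aromatic carbon gives an at least 2.0-fold higher number from compound 2 to compound 4 (0.30 log units; that floor lies within the scatter). That floor lies within the scatter, so the larger group brought no lower number, while the true size of the step stays unread. The reading of compound 4 is a limit and not a number: the limit of > 10000 nM in this assay, at which 1 of the 4 values shown sits.

The compounds shown leave open whether a smaller group here, such as a methylsulfonyl or a carboxamide, would match compound 2. They also leave open whether the sulfonyl or the methylpiperazine ring accounts for the change.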